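This account rests on a few compounds, and the source may have more. Where it says the series, first, only, none or still open, it means among the compounds named here.

Measured compounds:
- Compound 1 `C=C(Br)C(=O)Nc1cccc(-c2cn3nc(-c4ccc(CC)cc4)sc3n2)c1`: 2200 nM
- Compound 2 `Nc1cccc(-c2cn3nc(Cc4ccccc4)sc3n2)c1`: 7400 nM
- Compound 3 `C=C(Br)C(=O)Nc1cccc(-c2cn3nc(-c4ccc(C)cc4)sc3n2)c1`: 920 nM

In a functional assay on L1210 cells (Mus musculus) for inhibition, read by cell counting, with a stated time of 2 days (on this read-out higher numbers stand for weaker inhibition and lower numbers for stronger inhibition), compound 3 gives the lowest of the three numbers. Its nearest neighbour is compound 1, which in this assay gives 2200 nM; the furthest is compound 2, which in this assay gives 7400 nM. Within the data shown here, the one measured step, a 2.4-fold lower number from compound 1 to compound 3 (0.38 log units; beyond the scatter), shows a modest gain when the chain on the distal phenyl is shortened.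

Compound 4 `C=C(Br)C(=O)Nc1cccc(-c2cn3nc(-c4ccc(OC)cc4)sc3n2)c1` has not yet been measured. It differs from compound 3 by methoxy in place of methyl on an aromatic carbon. Among the measured compounds shown here, no measured step bears directly on this change: the only step available, a 2.4-fold lower number from compound 1 to compound 3 (0.38 log units; beyond the scatter), concerns the length of a saturated chain at the same position, not the exchange of a methyl for a methoxy. Compound 2 carries neither the acrylamide nor a substituted phenyl at that position, so its value cannot be separated into a single change either.

For the measured compounds named here, with no step to lean on, the expectation for compound 4 is a number close to that of compound 3, with a 1.2-fold higher number from compound 3 to compound 4 (0.08 log units; within the scatter) as the estimated step, in either direction and probably within the scatter. Compound 4 is therefore estimated at 1100 nM, with a range from 400 nM to 3000 nM.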

Compound 4, half-maximal inhibitory concentration: 940 nM
Estimate against measurement, compound 4: 1.2-fold (0.07 log units) above, and the stated range covers the measured number.
By their numbers in this assay, from the lowest: compounds 3 and 4 (each within the scatter of the next); then compound 1; then compound 2.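

In this assay, the exchange of methyl for methoxy on this aromatic carbon adds an oxygen and a hydrogen-bond acceptor, yet the step is a 1.0-fold higher number from compound 3 to compound 4 (0.01 log units; within the scatter) and so shows no readable difference between compound 3 and compound 4. Compound 1 now stands apart from two neighbours rather than one, with a 2.3-fold lower number from compound 1 to compound 4 (0.37 log units; beyond the scatter) joining a 2.4-fold lower number from compound 1 to compound 3 (0.38 log units; beyond the scatter) as a second modest step in the same direction. The earlier step alone could be read as a plain matter of chain size, but compound 4 shows that a group with more heavy atoms than methyl can sit here without a number beyond the scatter of compound 3, and among these compounds only the 4-ethylphenyl group of compound 1 goes with the higher number. No measurement among these data explains why methoxy and methyl read alike while ethyl does not.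

The compounds shown leave open whether an amine, a hydroxyl group, a carboxylic acid or a chain longer than ethyl at this position would stay level with compound 3 and compound 4. They also leave open what the bromoacrylamide contributes, since compound 2 differs from the others in more than one place.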